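The compounds below may be only part of what the source reports. "The series", "measured", "known", "first", "only" and "open" are said of these compounds alone.

Measured compounds:
Compound 1, `Cc1nc(-c2ccccc2NCC2=NCCN2)co1`, in a functional assay for activation of Alpha-1B adrenergic receptor (Homo sapiens), read by calcium flux (a higher number here means that more compound is needed for the effect, a lower number that less compound is needed), gives < 5020 nM, a limit of the assay and not a number.
Compound 2, `Cc1noc(-c2ccccc2NCC2=NCCN2)n1`, in this assay gives < 5020 nM, likewise a limit of the assay.
Compound 3, `c1ccc(-c2ccccc2NCC2=NCCN2)nc1`, in this assay gives 30.2 nM.

Among the measured compounds shown here, compound 3 thus carries the only number in the set; the other two values are limits, as the limit of < 5020 nM in this assay, at which 2 of the 3 values shown sit, records. The steps a step that the two limits leave unreadable from compound 1 to compound 2, a step that the limit leaves unreadable from compound 1 to compound 3 and a step that the limit leaves unreadable from compound 2 to compound 3 are all unreadable in size and give no measured gauge. Compound 4, `CC/C(=N\OC)c1ccccc1NCC1=NCCN1`, differs from compound 3 by a group of 6 heavy atoms (4 carbon, 1 nitrogen, 1 oxygen; no ring) in place of a group of 6 heavy atoms (5 carbon, 1 nitrogen; one six-membered aromatic ring with 1 hetero atom), on an aromatic carbon. For the measured compounds named here, no measured step exchanges a ring for an open chain, so the expected size rests on no direct comparison. Compound 4 is estimated in this assay at 120 nM, within 20 nM to 700 nM. The expected step is a 4.0-fold higher number from compound 3 to compound 4 (0.60 log units; beyond the scatter).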

Compound 4, half-maximal effective concentration: < 100000 nM
Compound 4: a limit, no number; the forecaster's own chance of this, stated with the estimate: 20%; the middle value lies beyond the limit too.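

In this assay compound 4 gives < 100000 nM, a limit of the assay and not a number, so its steps to compound 1, compound 2 and compound 3 cannot be read. Going by these compounds, the size of the change from pyridin-2-yl in compound 3 to the open chain in compound 4 remains open.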